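Methoxy on the benzamide of a 5-lipoxygenase chalcone series

This account rests on a few compounds, and the source may have more. Where it says the series, first, only, none or still open, it means among the compounds named here.

Measured compounds:
compound 1, `Cc1nc(NC(=O)c2ccccc2)sc1C(=O)/C=C/c1ccc(F)cc1`, 98%
compound 2, `Cc1nc(NC(=O)c2ccccc2)sc1C(=O)/C=C/c1ccc(Br)cc1`, 52.3%

Two compounds have been run in an assay for inhibition of Polyunsaturated fatty acid 5-lipoxygenase (Homo sapiens), read by spectrophotometry, tested at 10 uM, in the presence of a further agent that is not named here; on this read-out higher numbers stand for more inhibition at the one concentration tested (going by the name of the read-out) and lower numbers for less inhibition. Compound 1 stands highest of the two numbers; its nearest neighbour, compound 2, lies a number 45.7 percentage points lower from compound 1 to compound 2 (beyond the scatter), a change that comes from bromo in place of fluoro on an aromatic carbon.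

Compound 3, `COc1ccc(C(=O)Nc2nc(C)c(C(=O)/C=C/c3ccc(F)cc3)s2)cc1`, has not been measured. It differs from compound 1 by methoxy in place of hydrogen on an aromatic carbon. Among the compounds with values here, no measured step touches this part of the molecule: the single step known, from compound 1 to compound 2, alters the other aromatic ring, and its size says nothing about a methoxy on the benzamide. Compound 1 already sits near the top of the read-out, so there is little room upward.

Within the data shown here, with no bearing step, compound 3 is expected to show a number 13 percentage points lower from compound 1 to compound 3 (beyond the scatter), no change beyond the scatter, though with wide uncertainty. The estimate for compound 3 is 85%, ranging from 50% to 100%.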

Compound 3, a percentage reported as inhibition, at one concentration (the size of the read-out at that concentration, not a potency): 88.2%
Beside the measured number, compound 3's estimate is 3.2 percentage points below it; low and high end bracket the measured number.
By their numbers in this assay, from the lowest: compound 2; then compounds 3 and 1 (each within the scatter of the next).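

In this assay, within the data shown here, the first change on this ring, phenyl to 4-methoxyphenyl, gives a number 9.8 percentage points lower from compound 1 to compound 3 (within the scatter) and so leaves compound 3 and compound 1 indistinguishable on this read-out. This shows that the place para to a large group on the six-membered aromatic ring of carbon only can carry a methoxy without a change beyond the scatter, whereas the earlier step from fluoro to bromo concerned the other aromatic ring. No experimental evidence here explains this result.

As far as these compounds go, what remains open is whether a different group at this place, such as an amine, a carboxylic acid or a longer alkoxy chain, would also leave the read-out unchanged. The compounds shown also leave open whether methoxy would behave in the same way with bromo in place of fluoro on the other ring.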